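Trifluorophenyl Variant of a Trimethoxybenzoyl Pyrrole

This account rests on a few compounds, and the source may have more. Where it says the series, first, only, none or still open, it means among the compounds named here.

The shared core carries a trimethoxybenzoyl group on a five-membered aromatic ring with one nitrogen, which also bears a phenyl group. Compound 1 `COc1cc(C(=O)c2cn(-c3ccccc3)cc2-c2cccc(Br)c2)cc(OC)c1OC` gives 950 nM in a functional assay on MCF7 cells (Homo sapiens) for cytotoxicity, read by MTT assay, with a stated time of 96 h; a higher number here means a weaker inhibitor, a lower number a stronger inhibitor. Compound 2 `COc1cc(C(=O)c2cn(-c3ccccc3)cc2-c2cccc([N+](=O)[O-])c2)cc(OC)c1OC` gives 50 nM in this assay, and it stands lowest of the two numbers shown, with compound 1 as its nearest neighbour. For the measured compounds named here, the only measured step, a 19-fold lower number from compound 1 to compound 2 (1.28 log units; beyond the scatter), shows that the group on this aromatic carbon matters greatly.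

Compound 3 `COc1cc(C(=O)c2cn(-c3ccccc3)cc2-c2c(F)cc(F)cc2F)cc(OC)c1OC` differs from compound 2 by 2,4,6-trifluorophenyl in place of 3-nitrophenyl on an aromatic carbon. Going by the values given here, no measured step bears directly on a 2,4,6-trifluorophenyl group here, so the expectation rests on compound 2 and on the step from compound 1 to compound 2. Since the gain seen with the nitro group is unlikely to carry over, the number for compound 3 is expected to move as a 16-fold higher number from compound 2 to compound 3 (1.20 log units; beyond the scatter), landing near the level of compound 1. Compound 3 is therefore estimated at 800 nM, within a range from 150 nM to 4000 nM.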

Compound 3, half-maximal inhibitory concentration: 180 nM
Beside the measured number, compound 3's estimate is 4.4-fold (0.65 log units) above it; measured number inside the range.
By their numbers in this assay, from the lowest: compound 2; then compound 3; then compound 1.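

The position does not depend on the nitro group for a low number. In this assay, the ring without any hydrogen-bond acceptor gives back only part of the gain, with a 3.6-fold higher number from compound 2 to compound 3 (0.56 log units; beyond the scatter), while still keeping clear of the bromo compound, with a 5.3-fold lower number from compound 1 to compound 3 (0.72 log units; beyond the scatter). Thus two quite different aromatic groups on this carbon, 3-nitrophenyl and 2,4,6-trifluorophenyl, both give lower numbers than 3-bromophenyl, and no measurement on hand explains that order.

Compound 3 changes the number and the placement of its ring substituents at once, so the three compounds cannot say which of the fluorines count. On these data alone, how an amine, a nitrile or a single fluorine on that phenyl ring would compare also remains open.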